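The source may hold more compounds than are shown below. What is called first, only, known or untested is meant among the compounds shown, and "the series" means these compounds.

Going by the values given here, compound 1 `CC(C)C(Cc1ncc[nH]1)c1ccc(-c2ccc3cccc(F)c3c2)[nH]c1=O` is the only member of this set with a proper number in an ADME assay on microsomes from liver (Homo sapiens) for metabolic stability; a lower number here means that the compound disappears faster, a higher number that the compound lasts longer: compound 1 gives 0.106 h. Among the compounds with values here, compound 2 `CCn1ncc2c(F)cc(-c3ccc(C(CC)(CC)c4ncn(C)n4)c(=O)[nH]3)cc21` is reported in this assay only as a limit, > 3 h, not as a number, and it is the one value that sits there (the limit of > 3 h in this assay, at which 1 of the 2 values shown sits). Within the data shown here, no two measured compounds differ in a single place, so no measured step is available to calibrate a change. Compound 3 `CC(C)C(/C=C1/CCNC1=O)c1ccc(-c2ccc3cccc(F)c3c2)[nH]c1=O` has not yet been measured; it differs from compound 1 in one place: a group of 7 heavy atoms (5 carbon, 1 nitrogen, 1 oxygen; one five-membered non-aromatic ring with 1 hetero atom) in place of a group of 6 heavy atoms (4 carbon, 2 nitrogen; one five-membered aromatic ring with 2 hetero atoms), on a saturated chain carbon bound to an aromatic carbon and a saturated chain carbon. Among the measured compounds shown here, with no measured pair to lean on, the step expected in this assay is a 1.4-fold higher number from compound 1 to compound 3 (0.15 log units; within the scatter), a small one that may well stay within the usual scatter, its direction not settled by the data at hand. Compound 3 is therefore estimated at 0.15 h, with a range from 0.05 h to 0.5 h.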

Compound 3, half-life: 0.987 h
Compound 3: the middle estimate sits 6.6-fold (0.82 log units) below what was measured, outside the stated range (above it).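

Going by these compounds alone, at the saturated chain carbon bound to an aromatic carbon and a saturated chain carbon, exchanging the (1H-imidazol-2-yl)methyl group for the group with the five-membered non-aromatic ring gives the first measured step in this assay: a 9.3-fold higher number from compound 1 to compound 3 (0.97 log units; beyond the scatter), which lies beyond the usual scatter. This place on the core of compound 1 therefore matters in this read-out, and compound 3 lasts longer than compound 1. The two groups carry the same counts of hydrogen-bond donors and acceptors and no net charge, so those counts do not separate them.

From the compounds shown here alone, how other groups at this place, such as an amine, a carboxylic acid or a longer chain, would read in this assay stays open, as does which feature of the exchange carries the step. Nothing measured here bears on why the number rises at this place.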